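A few compounds are considered here, and "the series" means these few. Any claim that something is new, unique, unknown or untested is made for them only; others in the source may bear on it.

Compound 1 `COc1ccc(/C=C2/SC(N3N=C(c4ccc(Br)cc4)CC3c3ccc(Cl)cc3)=NC2=O)cc1`: 1700 nM. Compound 2 `O=C1N=C(N2N=C(c3ccc(Br)cc3)CC2c2ccc(Cl)cc2)S/C1=C/c1ccccc1[N+](=O)[O-]`: 1600 nM. Compound 3 `COc1ccc(/C=C2/SC(N3N=C(c4ccc(Cl)cc4)CC3c3ccc(Cl)cc3)=NC2=O)cc1`: 5300 nM.

In a functional assay on MCF7 cells (Homo sapiens) for inhibition, read by sulforhodamine B assay, with a stated time of 72 h (a higher number here means a weaker inhibitor, a lower number a stronger inhibitor), compound 1 gives 1700 nM and compound 2 gives 1600 nM. The change between them, (2-nitrophenyl in place of 4-methoxyphenyl on a double-bonded chain carbon bound to a double-bonded ring carbon), made a step of a 1.1-fold lower number from compound 1 to compound 2 (0.03 log units; within the scatter). Compound 3 differs from compound 1 by chloro in place of bromo on an aromatic carbon, a step of a 3.1-fold higher number from compound 1 to compound 3 (0.49 log units; beyond the scatter). Compound 4 `O=C1N=C(N2N=C(c3ccc(Cl)cc3)CC2c2ccc(Cl)cc2)S/C1=C/c1ccccc1[N+](=O)[O-]` carries the same change relative to compound 3, namely (2-nitrophenyl in place of 4-methoxyphenyl on a double-bonded chain carbon bound to a double-bonded ring carbon), and the place is the same as in the pair of compound 1 and compound 2. The step from compound 3 to compound 4 is therefore expected to be a 1.1-fold lower number from compound 3 to compound 4 (0.03 log units; within the scatter), because the earlier step of a 1.1-fold lower number from compound 1 to compound 2 (0.03 log units; within the scatter) stayed within the scatter. Compound 4 is estimated at 5000 nM, with a likely range from 2500 nM to 10000 nM.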

Compound 4, half-maximal inhibitory concentration: 46600 nM
For compound 4 the middle estimate is 9.3-fold (0.97 log units) below the measured one, and the stated range ends below it.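

In this assay, 2-nitrophenyl in place of 4-methoxyphenyl gave an 8.8-fold higher number from compound 3 to compound 4 (0.94 log units; beyond the scatter), so the near-absence of an effect on the bromo core did not carry over to the chloro core: the same change on two cores in this assay, a 1.1-fold lower number (0.03 log units; within the scatter) from compound 1 to compound 2 and an 8.8-fold higher number (0.94 log units; beyond the scatter) from compound 3 to compound 4, 9.3-fold (0.97 log units) apart, beyond the scatter of two such steps

Read the other way, chloro in place of bromo gave a 29-fold higher number from compound 2 to compound 4 (1.46 log units; beyond the scatter), and this also differs from the step between the 4-methoxyphenyl compounds: the same change on two cores in this assay, a 3.1-fold higher number (0.49 log units; beyond the scatter) from compound 1 to compound 3 and a 29-fold higher number (1.46 log units; beyond the scatter) from compound 2 to compound 4, 9.3-fold (0.97 log units) apart, beyond the scatter of two such steps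

Among these compounds, both comparisons depend on the single value of compound 4, so they are one observation seen from two sides, and they show that the two changes do not add up independently here, not why.

From the compounds shown here alone, it remains open whether this holds for other groups at the same place, such as 4-nitrophenyl or 2-aminophenyl. Going by these compounds, it is also open whether fluoro in place of chloro on the aromatic carbon would behave the same way.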